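The source may hold more compounds than are shown below. What is called first, only, known or untested is meant among the compounds shown, and "the series" means these compounds.

Working notes on the series. In an ADME assay (liver) for metabolic stability, with Liver microsome (Homo sapiens) as the target, using microsomes and NADPH, with a stated time of 30 min, tested at 1 uM (on this read-out higher numbers stand for fast clearance and lower numbers for slow clearance), compound 1 `COc1cc(C(O)(C(F)(F)F)C(F)(F)F)cnc1N1CCN(S(=O)(=O)c2ccc(N)nc2)CC1` reads < 14 mL.min-1.g-1, which is a limit of the assay and not a number. Within the data shown here, compound 2 `CC(C)n1cc(-c2cc(C(O)(C(F)(F)F)C(F)(F)F)cnc2N2CCN(S(=O)(=O)c3ccc(N)nc3)CC2)cn1` gives 38 mL.min-1.g-1, the only actual number so far. Among the measured compounds shown here, the single measured step, an at least 2.7-fold higher number from compound 1 to compound 2 (0.43 log units; beyond the scatter), put 1-isopropyl-1H-pyrazol-4-yl in place of methoxy on an aromatic carbon. Compound 3 `Cc1csc(-c2cc(C(O)(C(F)(F)F)C(F)(F)F)cnc2N2CCN(S(=O)(=O)c3ccc(N)nc3)CC2)c1` changes that same place, with 4-methylthiophen-2-yl in place of 1-isopropyl-1H-pyrazol-4-yl on an aromatic carbon. Both groups are one five-membered aromatic ring, whereas the measured step started from methoxy, so that step bears only indirectly. Starting from compound 2 at 38 mL.min-1.g-1, only a small upward move is expected in this assay, probably inside the usual scatter. The expected change is a 1.3-fold higher number from compound 2 to compound 3 (0.12 log units; within the scatter). For compound 3 the estimated value is 50 mL.min-1.g-1, with an expected range of 22 mL.min-1.g-1 to 110 mL.min-1.g-1.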

Compound 3, intrinsic clearance in microsomes: 29 mL.min-1.g-1
Compound 3: middle estimate off by 1.7-fold (0.24 log units), on the high side; low and high end bracket the measured number.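

In this assay, one five-membered aromatic ring in place of another at this position gives a 1.3-fold lower number from compound 2 to compound 3 (0.12 log units; within the scatter), so the read-out does not separate 1-isopropyl-1H-pyrazol-4-yl from 4-methylthiophen-2-yl, although the two groups differ in heavy atoms, hetero atoms and hydrogen-bond acceptors. Leaving methoxy for the second ring gives an at least 2.0-fold higher number from compound 1 to compound 3 (0.31 log units; beyond the scatter), so the rise beyond the scatter is now seen with two different five-membered aromatic rings, not with one alone. Compound 1 carries a limit and not a number, so the steps from it give only a minimum size: the limit of < 14 mL.min-1.g-1 in this assay, at which 1 of the 3 values shown sits.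

Open, going by these compounds, is whether the higher numbers go with an aromatic ring as such or simply with the loss of methoxy. A morpholine or an ethyl chain at this place would separate those two readings.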